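The compounds below may be only part of what the source reports. "The series", "measured", "known", "first", "only" and "open" are said of these compounds alone.

Measured compounds in an assay on cells for inhibition of Voltage-dependent T-type calcium channel subunit alpha-1H (Homo sapiens), read by FLIPR and calcium flux, with stated times of 600 s and 300 s; a higher number here means a weaker inhibitor, a lower number a stronger inhibitor:
- compound 1 `CN(Cc1ccc(OCCCNC(=N)N)cc1)c1nc2ccc(Oc3ccc(F)cc3)cc2s1`: 521000 nM
- compound 2 `CN(Cc1ccc(OCCCN)cc1)c1nc2ccc(Oc3ccc(F)cc3)cc2s1`: 492000 nM
- compound 3 `CN(Cc1ccc(OCCCN)cc1)c1nc2ccc(Oc3cccc(C(F)(F)F)c3)cc2s1`: 239000 nM

Compound 2 stands second highest of these three numbers. Its nearest neighbour is compound 1, and the step from compound 1 to compound 2 is a 1.1-fold lower number from compound 1 to compound 2 (0.02 log units; within the scatter), a hydrogen atom in place of a guanidine-like group on an amine nitrogen. The furthest is compound 3, reached by a 2.1-fold lower number from compound 2 to compound 3 (0.31 log units; beyond the scatter), where the aryl group on the ether oxygen is exchanged.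

Compound 4 `NCCCOc1ccc(CNc2nc3ccc(Oc4ccc(F)cc4)cc3s2)cc1` differs from compound 2 by hydrogen in place of methyl on a nitrogen on an aromatic ring. Among the measured compounds shown here, no measured step touches this nitrogen, so the two measured steps bear on it only indirectly: the change at the distal amine was within the scatter, and the change at the aryl ether was modest. Both show that this series moves little on single changes. A step within the scatter in this assay is therefore expected, a 1.1-fold lower number from compound 2 to compound 4 (0.04 log units; within the scatter). The estimate for compound 4 in this assay is 450000 nM, with a range from 200000 nM to 1000000 nM.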

Compound 4, half-maximal inhibitory concentration: 688000 nM
The estimate for compound 4 lay 1.5-fold (0.18 log units) below the measured number; low and high end bracket the measured number.
By their numbers in this assay, from the lowest: compound 3; then compounds 2, 1 and 4 (each within the scatter of the next).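

In this assay, among the compounds shown here, hydrogen in place of methyl on the nitrogen on an aromatic ring gives a 1.4-fold higher number from compound 2 to compound 4 (0.15 log units; within the scatter), the first measured step at this position. With 4-fluorophenyl on the ether oxygen, the methyl can therefore be removed without a change beyond the scatter, so compound 2 and compound 4 cannot be told apart on these numbers. Nothing available accounts for this result or ties it to any property of the methyl group.

The compounds shown leave open whether the same holds when 3-(trifluoromethyl)phenyl sits on the ether oxygen, as in compound 3. They also leave open what a larger group on this nitrogen, such as an ethyl, a cyclopropyl or an acetyl, would do to the number in this assay.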